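This account rests on a few compounds, and the source may have more. Where it says the series, first, only, none or still open, it means among the compounds named here.

Measured compounds in a physicochemical assay for permeability, using PAMPA, at pH 4; on this read-out lower numbers stand for lower permeability and higher numbers for higher permeability:
- compound 1 `CC(C)Nc1nc(NCc2ccco2)c2cccc(Cl)c2n1`: 67.6 10^-6 cm/s
- compound 2 `CC(C)Nc1nc(NCc2ccco2)c2ccc(Cl)cc2n1`: 103 10^-6 cm/s
- compound 3 `Cc1cccc2c(NCc3ccco3)nc(NC(C)C)nc12`: 45.9 10^-6 cm/s

Compound 1 and compound 2 hold the same atoms joined differently; the difference between the two cores is not broken down here, and their two values in this assay lie within the scatter of each other. Compound 3 differs from compound 1 by methyl in place of chloro on an aromatic carbon and this gave a 1.5-fold lower number from compound 1 to compound 3 (0.17 log units; within the scatter).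

Compound 4 `Cc1ccc2c(NCc3ccco3)nc(NC(C)C)nc2c1` is not yet measured. It differs from compound 2 by methyl in place of chloro on an aromatic carbon. The place is meta to a fused ring and para to a fused ring, whereas in the earlier pair it is ortho to a fused ring and meta to a fused ring, so this is the same kind of change, not the same change. For compound 4 the expected step is a 1.5-fold lower number from compound 2 to compound 4 (0.17 log units; within the scatter), because the earlier pair gave a 1.5-fold lower number from compound 1 to compound 3 (0.17 log units; within the scatter) in this assay. Compound 4 is thus estimated at 70 10^-6 cm/s, expected between 45 10^-6 cm/s and 110 10^-6 cm/s.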

Compound 4, apparent permeability: 67.2 10^-6 cm/s
For compound 4 the middle estimate is 1.0-fold (0.02 log units) above the measured one, within the range that was stated.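

In this assay methyl in place of chloro on an aromatic carbon gives a 1.5-fold lower number from compound 2 to compound 4 (0.19 log units; within the scatter) and the earlier pair gave a 1.5-fold lower number from compound 1 to compound 3 (0.17 log units; within the scatter) so on both cores the step lies within the scatter. The change therefore carries between these two cores, at two different places, without a step beyond the scatter, but two pairs with one swap do not show that it would hold on any other core. The data offer no measured account of either step.

On these data alone, what a methoxy, an amine or a carboxylic acid in place of chloro would give in this assay stays open. Also open, as far as these compounds go, is whether the methyl for chloro step holds at the remaining places on the six-membered aromatic ring.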